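The source may report more compounds than this note shows. Statements on the series, on what has been measured and on what is new or still open speak of the compounds shown alone.

In a functional assay on HepG2 cells (Homo sapiens) for cytotoxicity, read by MTT assay, with a stated time of 48 h (on this read-out higher numbers stand for weaker inhibition and lower numbers for stronger inhibition), compound 1 (`CC1=NN(C(=O)CN2CCCCC2)C(c2ccccc2O)C1`) gives 3020 nM and compound 2 (`CC(=O)Oc1ccccc1C1CC(C)=NN1C(=O)CN(C(C)C)C(C)C`) gives 34100 nM. Compound 2 thus holds the higher of the two numbers, by a gap beyond the scatter. Compound 3 (`CC(=O)Oc1ccccc1C1CC(C)=NN1C(=O)CN1CCCCC1`) departs from compound 2 in one place: piperidin-1-yl in place of diisopropylamino on a saturated chain carbon bound to a carbonyl carbon. Among the measured compounds shown here, no measured pair shows this change alone, since compound 1 and compound 2 also differ elsewhere. Even so, compound 1 carries piperidin-1-yl as well and stands at 3020 nM, which points towards a lower number in this assay. A moderate fall beyond the scatter is expected, and the estimated step is a 3.8-fold lower number from compound 2 to compound 3 (0.58 log units; beyond the scatter). For compound 3 the expected value is 9000 nM, with an estimated range of 2500 nM to 30000 nM.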

Compound 3, half-maximal inhibitory concentration: 19000 nM
For compound 3 the middle estimate is 2.1-fold (0.32 log units) below the measured one; the range from low to high includes it.
By their numbers in this assay, from the lowest: compound 1; then compounds 3 and 2 (each within the scatter of the next).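

In this assay, piperidin-1-yl in place of diisopropylamino on a saturated chain carbon bound to a carbonyl carbon gives a 1.8-fold lower number from compound 2 to compound 3 (0.25 log units; within the scatter), so with the acetyl group present, these two amines are not separated at this position. Among the compounds shown here, with piperidin-1-yl held fixed, acetyl in place of hydrogen on an oxygen on an aromatic ring gives a 6.3-fold higher number from compound 1 to compound 3 (0.80 log units; beyond the scatter), the only step here beyond the scatter. Nothing available explains either step.

The compounds shown leave open whether the amine change would read the same with the free hydroxyl on the aromatic ring. They also leave open how a morpholin-4-yl or dimethylamino group would stand on that chain carbon.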